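This account rests on a few compounds, and the source may have more. Where it says the series, first, only, none or still open, it means among the compounds named here.

Of the compounds shown here, two from this series have been measured in an assay on isolated protein for binding affinity to 5-hydroxytryptamine receptor 1B (Homo sapiens); a higher number here means a weaker inhibitor, a lower number a stronger inhibitor. Compound 1, `COc1cc2c(cc1N1C[C@@H](C)N(C)[C@@H](C)C1)N(C(=O)c1ccc(-c3cccc(C)n3)c3ccccc13)CC2`, gives 3.16 nM in this assay. Compound 2, `COc1cc2c(cc1N1C[C@@H](C)N[C@@H](C)C1)N(C(=O)c1ccc(-c3cccc(C)n3)c3ccccc13)CC2`, gives 50.1 nM in this assay, which is the higher of the two numbers recorded so far; its nearest neighbour is compound 1. Going by the values given here, the single measured step, hydrogen in place of methyl on an amine nitrogen in a ring, shows a 16-fold higher number from compound 1 to compound 2 (1.20 log units; beyond the scatter).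

Compound 3, `CCN1[C@H](C)CN(c2cc3c(cc2OC)CCN3C(=O)c2ccc(-c3cccc(C)n3)c3ccccc23)C[C@@H]1C`, is not yet measured. It differs from compound 2 in one place: ethyl in place of hydrogen on an amine nitrogen in a ring. Among the compounds with values here, this change reverses the direction of the one measured step, putting a small alkyl group back on the ring nitrogen that carries a hydrogen in compound 2, though ethyl rather than methyl. The measured step from compound 1 to compound 2 is the only one that bears on it, and it was large. The expectation for compound 3 in this assay is therefore a lower number than compound 2, a step of roughly a 10-fold lower number from compound 2 to compound 3 (1.00 log units; beyond the scatter), with the estimate for compound 3 being 5 nM and its expected range running from 2 nM to 20 nM.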

Compound 3, inhibition constant: 3.98 nM
The estimate for compound 3 lay 1.3-fold (0.10 log units) above the measured number; low and high end bracket the measured number.
By their numbers in this assay, from the lowest: compounds 1 and 3 (each within the scatter of the next); then compound 2.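

In this assay, going by these compounds alone, the amine nitrogen of the six-membered ring had so far been seen only with methyl and with hydrogen, and the new result shows that the effect of the earlier step is not limited to methyl: ethyl in place of hydrogen gives a 13-fold lower number from compound 2 to compound 3 (1.10 log units; beyond the scatter), a step printed as large, like the earlier 16-fold higher number from compound 1 to compound 2 (1.20 log units; beyond the scatter), but running the opposite way. The comparison of the two alkyl groups gives a 1.3-fold higher number from compound 1 to compound 3 (0.10 log units; within the scatter), so the added carbon makes no difference that can be read at this position, and among these three compounds, compound 2, with hydrogen on this nitrogen, is the one that stands apart. No measurement available here gives a reason for either the large steps or the absence of a readable change from methyl to ethyl.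

The compounds shown leave open how far this tolerance extends, for instance whether a longer chain such as propyl, a branched isopropyl group or a cyclopropyl ring on the same nitrogen would keep the number close to those of compound 1 and compound 3. They also leave open whether the same steps would hold without the two methyl groups on the neighbouring ring atoms.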